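Swapping Phenyl for an Isoxazole on the Amide Nitrogen

This account rests on a few compounds, and the source may have more. Where it says the series, first, only, none or still open, it means among the compounds named here.

Measured compounds:
compound 1 `Cc1ccc(OCC(=O)N(Cc2cccs2)c2nccn2C)cc1`: 1790 nM
compound 2 `Cc1ccc(OCC(=O)N(Cc2cccs2)c2ccccc2)cc1`: 23 nM

For the measured compounds named here, in an assay on HEK293 cells for agonist activity at transient receptor potential cation channel subfamily M member 8 (Homo sapiens), read by fluorescence and calcium flux, with a stated time of 15 min (a higher number here means that more compound is needed for the effect, a lower number that less compound is needed), compound 2 stands lowest of the two numbers; the one measured step is a 78-fold lower number from compound 1 to compound 2 (1.89 log units; beyond the scatter), a large move toward less compound needed when a five-membered aromatic ring gave way to phenyl. Compound 3 `Cc1ccc(OCC(=O)N(Cc2cccs2)c2ccon2)cc1` reverses that kind of exchange: 1,2-oxazol-3-yl in place of phenyl on an amide-type nitrogen. That single step bears on it, so the number is expected to rise, though 1,2-oxazol-3-yl is not the ring that was lost before and the size is uncertain. Compound 3 is therefore estimated at 300 nM, between 60 nM and 1500 nM, an expected step of a 13-fold higher number from compound 2 to compound 3 (1.12 log units; beyond the scatter).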

Compound 3, half-maximal effective concentration: 2 nM
Compound 3: the middle estimate sits 150-fold (2.18 log units) above what was measured; the measured number lies below the stated range.
By their numbers in this assay, from the lowest: compound 3; then compound 2; then compound 1.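

In this assay the exchange of phenyl for 1,2-oxazol-3-yl on the amide-type nitrogen gives a 12-fold lower number from compound 2 to compound 3 (1.06 log units; beyond the scatter) and so a five-membered aromatic ring with 2 hetero atoms can outdo phenyl at this place. Ring size alone does not decide the outcome: 1,2-oxazol-3-yl in place of 1-methyl-1H-imidazol-2-yl, another five-membered ring, gives a 900-fold lower number from compound 1 to compound 3 (2.95 log units; beyond the scatter) at the same place. Nothing measured here explains the difference between these rings.

Still open, from the compounds shown here alone, is how a saturated ring such as cyclohexyl or a small chain such as methyl would fare on this nitrogen. Also open, going by these compounds, is whether the gain stays with 1,2-oxazol-3-yl or extends to a ring such as pyridin-2-yl.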